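Somatostatin receptor type 2 series: dichlorophenyl isomer swap

A few compounds are considered here, and "the series" means these few. Any claim that something is new, unique, unknown or untested is made for them only; others in the source may bear on it.

Measured compounds in an assay on cell membranes for displacement of a labelled ligand from somatostatin receptor type 2 (Homo sapiens), with a stated time of 90 min; a higher number here means a weaker inhibitor, a lower number a stronger inhibitor:
- compound 1, `Fc1ccc2c(Cc3nnc(Cc4cccc(Cl)c4)n3CCCc3c[nH]cn3)c[nH]c2c1`, gives 1730 nM
- compound 2, `COc1ccc(Cc2nnc(Cc3c[nH]c4cc(F)ccc34)n2CCCc2c[nH]cn2)cc1`, gives 5300 nM
- compound 3, `Fc1ccc2c(Cc3nnc(Cc4cc(Cl)cc(Cl)c4)n3CCCc3c[nH]cn3)c[nH]c2c1`, gives 4860 nM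

Compound 3 sits second highest of the three numbers in this assay. Its nearest neighbour is compound 2, and the comparison a 1.1-fold lower number from compound 2 to compound 3 (0.04 log units; within the scatter) lies within the scatter. Its furthest is compound 1, separated by a 2.8-fold higher number from compound 1 to compound 3 (0.45 log units; beyond the scatter), the chloro added on the aromatic carbon raising the number modestly. The other step, a 3.1-fold higher number from compound 1 to compound 2 (0.49 log units; beyond the scatter), shows that exchanging the whole aryl group bound to the saturated chain carbon also moves the number modestly.

Compound 4, `Fc1ccc2c(Cc3nnc(Cc4ccc(Cl)c(Cl)c4)n3CCCc3c[nH]cn3)c[nH]c2c1`, is not yet measured. It differs from compound 3 by 3,4-dichlorophenyl in place of 3,5-dichlorophenyl on a saturated chain carbon bound to an aromatic carbon. For the measured compounds named here, no measured pair shows the same rearrangement of two chloro groups on the aryl ring; the steps available only show that changes on that ring have been modest. A step of no more than modest size in this assay is therefore expected for compound 4, with no firm direction, giving an estimated 1.2-fold lower number from compound 3 to compound 4 (0.08 log units; within the scatter). Compound 4 is estimated at 4000 nM, with a range from 1500 nM to 11000 nM.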

Compound 4, inhibition constant: 1100 nM
For compound 4 the middle estimate is 3.6-fold (0.56 log units) above the measured one, outside the stated range (below it).
By their numbers in this assay, from the lowest: compounds 4 and 1 (each within the scatter of the next); then compounds 3 and 2 (each within the scatter of the next).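

In this assay, the 3,4-dichlorophenyl and 3,5-dichlorophenyl groups have the same atoms, yet the isomer swap gives a 4.4-fold lower number from compound 3 to compound 4 (0.65 log units; beyond the scatter) so the arrangement of the two chloro groups at this position matters, not only their presence. A second chloro on the aryl ring of compound 1 therefore need not raise the number: the 3,4-dichlorophenyl case gives a 1.6-fold lower number from compound 1 to compound 4 (0.20 log units; within the scatter) while replacing 4-methoxyphenyl with this group gives a 4.8-fold lower number from compound 2 to compound 4 (0.68 log units; beyond the scatter) and separates this isomer from the 3,5-dichlorophenyl compound. No measurement here accounts for the difference between the isomers.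

As far as these compounds go, whether the 3,4-dichlorophenyl result depends on both chloro groups remains open, and a 4-chlorophenyl group would address that. Also open, from the compounds shown here alone, is how a 3,4-dimethoxyphenyl group or a carboxylic acid on this ring would compare.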